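The source may hold more compounds than are shown below. What is called first, only, known or untested is meant among the compounds shown, and "the series" means these compounds.

Compound 1 `CC1CC/C(=N\Nc2ccc(O)cc2)c2ncc(C(=O)O)c(=O)n21` — in a functional assay on the whole organism for inhibition, with Rattus norvegicus as the target (on this read-out lower numbers stand for an effect already at smaller amounts and higher numbers for an effect only at larger amounts of compound), compound 1 gives > 100 umol/kg, a limit of the assay.
Compound 2 `C[C@@H]1CC/C(=N\Nc2ccc(O)cc2)c2ncc(C(=O)O)c(=O)n21` — in this assay compound 2 gives > 100 umol/kg, again a limit.
Compound 3 `C[C@H]1CC/C(=N\Nc2ccc(O)cc2)c2ncc(C(=O)O)c(=O)n21` — not yet measured.

Compound 2 stands at a limit in this assay and not at a number. Compound 3 differs from compound 2 in this way: the two compounds have the same atoms and bonds and differ only in configuration as drawn: 1 of 2 stereo elements differ; a stereocentre at a saturated ring carbon is drawn R in compound 2 and S in compound 3. Among the measured compounds shown here, the one measured step that bears on this is a step that the two limits leave unreadable from compound 1 to compound 2, which stays unreadable because the limit of > 100 umol/kg in this assay, at which 2 of the 2 values shown sit, and (the fact that one of compounds 1 and 2 is drawn with a defined configuration and the other without, at the place where they differ). No size or direction can therefore be expected beyond the scatter. Compound 3 is expected to give 200 umol/kg in this assay, within 50 umol/kg to 1000 umol/kg. The expected step that the limit leaves unreadable from compound 2 to compound 3 is most likely another limit.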

Compound 3, dose for 50% inhibition: > 100 umol/kg
Compound 3 gave a limit, no number; the forecaster's own chance of this, stated with the estimate: 80%; the middle value lies beyond the limit too.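

In this assay compound 3 gives > 100 umol/kg, a limit. Among the compounds shown here, compounds 1, 2 and 3 all stand at limits, and no step among them can be read. On these data alone, whether R or S configuration at the saturated ring carbon changes the read-out stays open.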